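The source may hold more compounds than are shown below. What is called first, only, known or untested is meant among the compounds shown, and "the series" means these compounds.

Compound 1 `CCCCCCCC/C=C\CCCCCCCC(=O)OC[C@H]1O[C@H](CC2=CCCCC2)C=CC1=O` and compound 2 `CCCC(=O)OC[C@H]1O[C@H](CC2=CCCCC2)C=CC1=O` share a core that carries the (cyclohex-1-en-1-yl)methyl group; how their two cores differ is not broken down here. In a functional assay on LFCl2A cells (Rattus norvegicus) for cytotoxicity (on this read-out lower numbers stand for stronger inhibition and higher numbers for weaker inhibition), compound 1 gives 80 nM, and compound 2 gives 90 nM, two numbers that lie within the scatter of each other. Compound 3 `CCCC(=O)OC[C@H]1O[C@H](C2CCCC=C2C)C=CC1=O` is reached from compound 2 by one change, (2-methylcyclohex-2-en-1-yl in place of (cyclohex-1-en-1-yl)methyl on a saturated ring carbon). In this assay compound 3 gives 350 nM, so that a 3.9-fold higher number from compound 2 to compound 3 (0.59 log units; beyond the scatter).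

Compound 4 `CCCCCCCC/C=C\CCCCCCCC(=O)OC[C@H]1O[C@H](C2CCCC=C2C)C=CC1=O` stands to compound 1 as compound 3 stands to compound 2: the change is 2-methylcyclohex-2-en-1-yl in place of (cyclohex-1-en-1-yl)methyl on a saturated ring carbon. It is the same kind of change, though the surroundings differ in wording: the ring atom two ring bonds away bears a large group in compound 1 and a ((propylcarbonyl)oxy)methyl group in compound 2. On the strength of a 3.9-fold higher number from compound 2 to compound 3 (0.59 log units; beyond the scatter) he expects a step of similar size, a 3.9-fold higher number from compound 1 to compound 4 (0.59 log units; beyond the scatter), in this assay. His estimate for compound 4 in this assay is therefore 310 nM, with a likely range from 150 nM to 650 nM.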

Compound 4, half-maximal inhibitory concentration: 50 nM
Beside the measured number, compound 4's estimate is 6.2-fold (0.79 log units) above it, and the stated range ends above it.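

The new step shows that this change does not carry over from one core to the other in this assay: the same change on two cores in this assay, a 3.9-fold higher number (0.59 log units; beyond the scatter) from compound 2 to compound 3 and a 1.6-fold lower number (0.20 log units; within the scatter) from compound 1 to compound 4, 6.2-fold (0.79 log units) apart, beyond the scatter of two such steps. On the core of compound 1 the outcome is a 1.6-fold lower number from compound 1 to compound 4 (0.20 log units; within the scatter), so the rise in the number seen on the core of compound 2 does not reappear, and a step measured on one of these cores gave no safe estimate for the other. This does not show which feature of the large group on the core of compound 1 sets the two steps apart, nor does it give a rule for the series, since it rests on just two matched pairs.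

The compounds shown leave open how the step behaves on cores with other groups in that place, such as a free hydroxymethyl group, an octanoyl ester or an amide in place of the ester. They also leave open whether a plain cyclohexyl or a phenyl group on the same ring carbon would depend on the core in the same way.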